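Series notes: chloro in place of methyl, compound 4

The source may report more compounds than this note shows. Statements on the series, on what has been measured and on what is new or still open speak of the compounds shown alone.

Measured in a functional assay on HepG2 cells (Homo sapiens) for antiproliferative activity, read by MTT assay, with a stated time of 48 h; a lower number here means a stronger inhibitor, a higher number a weaker inhibitor:
compound 1, `Cc1ccc(NC(=O)Nc2cccc(CNc3nccnc3Cl)c2)cc1Cl`, gives 11300 nM
compound 2, `CCc1ccc(NC(=O)Nc2cccc(CNc3nccnc3Cl)c2)c(CC)c1`, gives 10800 nM
compound 3, `CC(C)(C)c1ccc(NC(=O)Nc2cccc(CNc3nccnc3Cl)c2)cc1`, gives 7550 nM

The three measured compounds share one core and differ only in the substitution of the outer aromatic ring. Compound 1 holds the highest of the three numbers, but neither its distance to compound 2 nor its distance to compound 3 reaches beyond the usual scatter of this assay, so the three read as one level rather than a ranking. Going by the values given here, no single-change step between measured compounds is at hand, so nothing in the measured set tells how an exchange of this kind has moved the read-out before.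

Compound 4, `O=C(Nc1cccc(CNc2nccnc2Cl)c1)Nc1ccc(Cl)c(Cl)c1`, is the next point. It differs from compound 1 in one place:

chloro in place of methyl on an aromatic carbon

Among the compounds with values here, with the measured compounds sitting within the scatter of one another, and with no directly comparable step to lean on, the exchange of a one-atom group for another one-atom group at the same place is expected to move the read-out little. The step of a 1.3-fold lower number from compound 1 to compound 4 (0.10 log units; within the scatter) is therefore expected to stay within the scatter, with a slight lean toward a lower number that is not to be trusted. On that basis compound 4 is estimated at 9000 nM, in the range 4000 nM to 22000 nM.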

Compound 4, half-maximal inhibitory concentration: 6170 nM
Estimate against measurement, compound 4: 1.5-fold (0.16 log units) above; the measured number falls inside the stated range.
By their numbers in this assay, from the lowest: compounds 4, 3, 2 and 1 (each within the scatter of the next).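

In this assay, going by these compounds alone, the exchange of methyl for chloro gives a 1.8-fold lower number from compound 1 to compound 4 (0.26 log units; within the scatter) as the first single-change step, at a place on the outer ring that is ortho to a chloro group and para to a large group. This step shows that 3-chloro-4-methylphenyl and 3,4-dichlorophenyl cannot be told apart in this read-out, so this position accepts a swap between these two one-atom groups without a shift beyond the scatter; with a single step, this holds only for this pair and this ring setting. No measurement bearing on the reason for this outcome is available.

The compounds shown leave open whether a larger or differently built group at this place, such as a methoxy group, an amine, a carboxylic acid or a longer chain, would move the number beyond the scatter. They also leave open whether the same exchange of methyl for chloro would read alike with hydrogen instead of the neighbouring chloro group, or at another carbon of the ring.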